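A few compounds are considered here, and "the series" means these few. Any claim that something is new, unique, unknown or untested is made for them only; others in the source may bear on it.

Values in a functional assay on A-375 cells (Homo sapiens) for antiproliferative activity; on this read-out lower numbers stand for stronger inhibition and higher numbers for weaker inhibition:
- compound 1 `O=C(Nc1ccc(-c2ccncc2)cc1)C1CCCN(Cc2ccc(F)c(F)c2)C1`: 600 nM
- compound 2 `O=C(Nc1ccc(-c2ccccn2)cc1)C1CCCN(Cc2ccc(F)c(F)c2)C1`: 9000 nM
- compound 3 `O=C(Nc1ccc(-c2c[nH]cn2)cc1)C1CCCN(Cc2ccc(F)c(F)c2)C1`: > 20000 nM (a limit of the assay, not a number)

Compound 3 has no numerical value and stands only at a limit, (the limit of > 20000 nM in this assay, at which 1 of the 3 values shown sits).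

The next compound is compound 4 `O=C(Nc1ccc(-c2ccoc2)cc1)C1CCCN(Cc2ccc(F)c(F)c2)C1`, with furan-3-yl in place of 1H-imidazol-4-yl on an aromatic carbon, para to a large group: furan-3-yl in place of 1H-imidazol-4-yl on an aromatic carbon.

Going by the values given here, no measured step involves furan-3-yl, so the evidence is indirect. Two steps end at the limit of compound 3: an at least 33-fold higher number from compound 1 to compound 3 (1.52 log units; beyond the scatter) and an at least 2.2-fold higher number from compound 2 to compound 3 (0.34 log units; beyond the scatter). The first is large and the second at least modest. The remaining step, a 15-fold higher number from compound 1 to compound 2 (1.18 log units; beyond the scatter), is also large, so exchanging one aromatic group for another in this place can move the read-out substantially.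

Among the compounds with values here, with only three compounds, the direction is a tentative expectation. A lower number than for compound 3 is expected, on the precedent of compound 2 at 9000 nM, with a return to the level of compound 1 not expected. The expected step is an at least 3.3-fold lower number from compound 3 to compound 4 (0.52 log units; beyond the scatter), and its size is poorly defined. For compound 4 the estimated value is 6000 nM, with an expected range of 1500 nM to 20000 nM.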

Compound 4, half-maximal inhibitory concentration: 1290 nM
Estimate against measurement, compound 4: 4.7-fold (0.67 log units) above; the whole stated range lies above it.
By their numbers in this assay, from the lowest: compound 1; then compound 4; then compound 2. At a limit, above all of these: compound 3.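

In this assay, a five-membered aromatic ring on this aromatic carbon, para to a large group, does not by itself abolish activity: furan-3-yl in place of 1H-imidazol-4-yl gives an at least 15-fold lower number from compound 3 to compound 4 (1.19 log units; beyond the scatter), with the entering group carrying 0 hydrogen-bond donors and the leaving group 1. Compound 3 stands only at a limit of the assay, not at a number, so the true size of this step stays unknown: the limit of > 20000 nM in this assay, at which 1 of the 4 values shown sits.

Compound 4 has no ring nitrogen, yet pyridin-2-yl compares poorly with furan-3-yl, as a 7.0-fold lower number from compound 2 to compound 4 (0.84 log units; beyond the scatter) shows, while pyridin-4-yl keeps the lowest number in the series, as a 2.2-fold higher number from compound 1 to compound 4 (0.33 log units; beyond the scatter) shows, so among these four compounds a ring nitrogen is neither sufficient nor required for activity, and its place in the ring matters.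

Open, going by these compounds, is how phenyl, pyridin-3-yl or thiophen-3-yl would compare at this place, which would help separate the effect of the ring nitrogen from that of ring size. Also open, on these data alone, is whether the hydrogen-bond donor of compound 3 accounts for its standing, since an N-methylimidazole would be needed to test this.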